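A few compounds are considered here, and "the series" means these few. Any claim that something is new, unique, unknown or untested is made for them only; others in the source may bear on it.

Measured compounds:
Compound 1, `NCCCOc1ccc(CNc2nc3ccc(Oc4ccc(C(F)(F)F)cc4)cc3s2)cc1`: 59000 nM
Compound 2, `CN(Cc1ccc(OCCCN)cc1)c1nc2ccc(Oc3ccc(C(F)(F)F)cc3)cc2s1`: 283000 nM

The two compounds share one core and differ only at a nitrogen on an aromatic ring. In an assay on SH-SY5Y cells for inhibition of Voltage-dependent N-type calcium channel subunit alpha-1B (Homo sapiens), read by FLIPR and calcium flux, with stated times of 600 s and 300 s, in the presence of a further agent that is not named here (a lower number here means a stronger inhibitor, a higher number a weaker inhibitor), compound 1 gives 59000 nM, the lower of the two numbers. Among the compounds with values here, compound 2 gives 283000 nM in this assay, and the single step, methyl in place of hydrogen on that nitrogen, reads a 4.8-fold higher number from compound 1 to compound 2 (0.68 log units; beyond the scatter).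

Compound 3, `NCCCOc1ccc(CNc2nc3ccc(Oc4ccc(F)cc4)cc3s2)cc1`, has not yet been measured. It differs from compound 1 at the other end of the molecule: fluoro in place of trifluoromethyl on an aromatic carbon. Within the data shown here, no measured step touches this part of the structure; the only step on record, from compound 1 to compound 2, concerns the ring nitrogen and says nothing about the phenoxy group. The expectation for compound 3 therefore rests on compound 1 alone, and a small weakening is guessed rather than derived. Compound 3 is expected to give about 100000 nM in this assay, between 30000 nM and 400000 nM, which would be a step of a 1.7-fold higher number from compound 1 to compound 3 (0.23 log units; within the scatter).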

Compound 3, half-maximal inhibitory concentration: 106000 nM
Compound 3: the middle estimate sits 1.1-fold (0.03 log units) below what was measured; low and high end bracket the measured number.
By their numbers in this assay, from the lowest: compounds 1 and 3 (each within the scatter of the next); then compound 2.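

Within this assay, the swap of 4-(trifluoromethyl)phenoxy for 4-fluorophenoxy gives the first reading at this end of the molecule: a 1.8-fold higher number from compound 1 to compound 3 (0.25 log units; within the scatter). Trifluoromethyl can thus give way to the single fluoro atom on this aromatic carbon, para to a large group, with no change that can be told from the scatter, whereas the methyl on the nitrogen, a 4.8-fold higher number from compound 1 to compound 2 (0.68 log units; beyond the scatter), lies beyond it, so of the two places changed in the shared core, only the nitrogen has so far shown a step larger than the scatter. No evidence is available on why these two groups read alike in this assay.

The compounds shown leave open how other groups at the same ring carbon would read, such as a hydrogen, a chlorine atom, a methoxy group or a nitrile, and so whether this position tolerates change broadly or only these two groups read alike. They also leave open whether methyl on the nitrogen would give a similar step with fluoro in place of trifluoromethyl, and how a longer chain carrying the amine would read.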